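Aryl substituent changes on the shared core: compound 4

The source may hold more compounds than are shown below. What is called first, only, known or untested is meant among the compounds shown, and "the series" means these compounds.

Compound 2 `Cc1cccc(CNc2ncnc3c2ncn3[C@@H]2O[C@H](CO)[C@@H](O)[C@H]2O)c1` carries a 3-methylphenyl on a saturated chain carbon bound to a nitrogen on an aromatic ring. In a functional assay on G-361 cells (Homo sapiens) for antiproliferative activity, with a stated time of 72 h (on this read-out higher numbers stand for weaker inhibition and lower numbers for stronger inhibition), compound 2 reaches only the limit of the assay, > 166000 nM, and no number. Compound 1 `OC[C@H]1O[C@@H](n2cnc3c(NCc4ccc(Br)cc4)ncnc32)[C@H](O)[C@@H]1O` likewise gives only a limit, > 166000 nM. Within the data shown here, compound 3 `OC[C@H]1O[C@@H](n2cnc3c(NCc4ccc(Cl)c(Cl)c4)ncnc32)[C@H](O)[C@@H]1O` is the one measured number in this assay, at 145000 nM. The step that the two limits leave unreadable from compound 1 to compound 2 cannot be read, since both ends are limits; the steps of an at least 1.1-fold lower number from compound 1 to compound 3 (0.05 log units; that floor lies within the scatter) and an at least 1.1-fold lower number from compound 2 to compound 3 (0.05 log units; that floor lies within the scatter) give only floors, each within the scatter, so the series clusters at the limit of > 166000 nM in this assay, at which 2 of the 3 values shown sit.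

Compound 4 `OC[C@H]1O[C@@H](n2cnc3c(NCc4ccc(F)cc4F)ncnc32)[C@H](O)[C@@H]1O` differs from compound 2 by 2,4-difluorophenyl in place of 3-methylphenyl on a saturated chain carbon bound to a nitrogen on an aromatic ring. The halogen-bearing rings of compound 1 and compound 3 and the methyl-bearing ring of compound 2 have given no step beyond the scatter on any readable pair, so nothing beyond the scatter is expected from this change either. Compound 4 is therefore expected at 170000 nM, within 100000 nM to 400000 nM, most probably again reported only as a limit. The expected step that the limit leaves unreadable from compound 2 to compound 4 is taken to be none beyond the scatter.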

Compound 4, half-maximal inhibitory concentration: > 166000 nM
Compound 4 ended at the assay's limit (the forecaster's own chance of this, stated with the estimate: 70%); the middle value is on the limit's open side.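

Compound 4 shows that 2,4-difluorophenyl on a saturated chain carbon bound to a nitrogen on an aromatic ring, with fluorine where compound 1 carries bromine and compound 3 carries chlorine, also gives only a limit in this assay. Among these compounds, the one readable new step is an at least 1.1-fold higher number from compound 3 to compound 4 (0.05 log units; that floor lies within the scatter), so the single measured number is still not set apart, and the other new steps join two limits and cannot be read. Changing the ring substituents has so far left the series where it was: the limit of > 166000 nM in this assay, at which 3 of the 4 values shown sit.

Still open, from the compounds shown here alone, is whether any group at this place gives a number clear of the limit, for instance a longer chain in place of the benzyl, or an amine or a carboxylic acid on the ring. The compounds shown also leave open whether a change elsewhere on the shared core would move these values.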